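The source may hold more compounds than are shown below. What is called first, only, known or untested is meant among the compounds shown, and "the series" means these compounds.

In an ADME assay on Vero cells (Chlorocebus sabaeus) for cytotoxicity, read by reporter gene assay, with a stated time of 4 days (a higher number here means a weaker inhibitor, a lower number a stronger inhibitor), compound 1 `CCCCCC(=O)NCC(C)(C)CC1=C(O)C(=O)c2ccccc2C1=O` gives 46600 nM, compound 2 `CCCCCCCC(=O)NCC(C)(C)CC1=C(O)C(=O)c2ccccc2C1=O` gives 18400 nM and compound 3 `CCCCCCCCC(=O)NCC(C)(C)CC1=C(O)C(=O)c2ccccc2C1=O` gives 16700 nM. Compound 3 thus stands within the scatter of compound 2 and beyond it from compound 1. Compound 4 `CCCCCCCCCC(=O)NCC(C)(C)CC1=C(O)C(=O)c2ccccc2C1=O` differs from compound 3 by methyl in place of hydrogen on a saturated chain carbon, eight bonds along the chain from a carbonyl carbon. The modest changes a 2.5-fold lower number from compound 1 to compound 2 (0.40 log units; beyond the scatter) and a 2.8-fold lower number from compound 1 to compound 3 (0.45 log units; beyond the scatter) involve larger additions. Going by the values given here, the closest precedent is the methyl addition seven bonds along the chain, a 1.1-fold lower number from compound 2 to compound 3 (0.04 log units; within the scatter), so no change beyond the scatter is expected in this assay. The expected step is a 1.1-fold lower number from compound 3 to compound 4 (0.05 log units; within the scatter). Compound 4 is estimated at 15000 nM, with an expected range of 8000 nM to 26000 nM.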

Compound 4, half-maximal inhibitory concentration: 15000 nM
The estimate for compound 4 equals the measured number at the digits printed, and the stated range covers the measured number.
By their numbers in this assay, from the lowest: compounds 4, 3 and 2 (each within the scatter of the next); then compound 1.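

In this assay, extending the chain further leaves the number level: methyl eight bonds along the chain gives (a 1.1-fold lower number from compound 3 to compound 4 (0.05 log units; within the scatter)) and ethyl seven bonds along gives (a 1.2-fold lower number from compound 2 to compound 4 (0.09 log units; within the scatter)), so compound 2, compound 3 and compound 4 sit at one level. Only the butyl comparison from the shortest chain clears the scatter (a 3.1-fold lower number from compound 1 to compound 4 (0.49 log units; beyond the scatter)), leaving compound 1 apart from the other three. Nothing measured here accounts for this level.

Going by these compounds, whether a longer chain stays at this level remains open. So does the effect of an amine or a carboxylic acid at the chain end.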